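Swapping the Indole Ring for a Dienyl Chain

The compounds below may be only part of what the source reports. "The series", "measured", "known", "first", "only" and "open" are said of these compounds alone.

Of the compounds shown here, three have been measured in a functional assay on SiHa cells (Homo sapiens) for cytotoxicity, read by MTT assay, with a stated time of 48 h; a lower number here means a stronger inhibitor, a higher number a weaker inhibitor. Compound 1 `C/C=C/C=C/C(=O)N[C@H](C(=O)NCCCCCCCC)[C@@H](C)O` gives 123000 nM, compound 2 `CCCCCCCCCCCCNC(=O)[C@@H](NC(=O)c1cc2ccccc2o1)[C@@H](C)O` gives 12900 nM, and compound 3 `CCCCCCCCCCCCNC(=O)[C@@H](NC(=O)c1cc2ccccc2[nH]1)[C@@H](C)O` gives 21300 nM. Compound 3 thus holds the second highest of the three numbers; its nearest neighbour is compound 2, separated by a 1.7-fold higher number from compound 2 to compound 3 (0.22 log units; within the scatter), while compound 1 lies furthest, with a number higher by a margin beyond the scatter. Compound 4 `C/C=C/C=C/C(=O)N[C@H](C(=O)NCCCCCCCCCCCC)[C@@H](C)O` differs from compound 3 by penta-1,3-dien-1-yl in place of 1H-indol-2-yl on a carbonyl carbon. Among the measured compounds shown here, no measured step makes this exact exchange, and the single measured step, a 1.7-fold higher number from compound 2 to compound 3 (0.22 log units; within the scatter), swaps one ring for another and so offers little guidance. Compound 1 carries the same penta-1,3-dien-1-yl group and gives 123000 nM. On that basis compound 4 is expected to shift by about a 2.8-fold higher number from compound 3 to compound 4 (0.45 log units; beyond the scatter). Compound 4 is estimated at 60000 nM, with a likely range of 20000 nM to 160000 nM.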

Compound 4, half-maximal inhibitory concentration: > 200000 nM
Compound 4 was reported as a limit (the forecaster's own chance of this, stated with the estimate: 10%); middle value at least 3.3-fold (0.52 log units) away from the limit.
By their numbers in this assay, from the lowest: compounds 2 and 3 (each within the scatter of the next); then compound 1. At a limit, above all of these: compound 4.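

Compound 4 is reported only as a limit: the limit of > 200000 nM in this assay, at which 1 of the 4 values shown sits. Penta-1,3-dien-1-yl on a carbonyl carbon therefore gives a much weaker result than either ring group when the rest of the molecule is unchanged, with an at least 9.3-fold higher number from compound 3 to compound 4 (0.97 log units; beyond the scatter) for 1H-indol-2-yl and an at least 15-fold higher number from compound 2 to compound 4 (1.19 log units; beyond the scatter) for 1-benzofuran-2-yl. Butyl in place of hydrogen on the saturated chain cannot be judged, as the step is an at least 1.6-fold higher number from compound 1 to compound 4 (0.21 log units; that floor lies within the scatter).

The compounds shown leave open whether a phenyl group on that carbonyl carbon would stay close to compound 3. They also leave open how a saturated pentyl group would compare with compound 4.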